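The source may hold more compounds than are shown below. What is called first, only, known or untested is meant among the compounds shown, and "the series" means these compounds.

Measured compounds in an ADME assay on Vero cells (Chlorocebus sabaeus) for cytotoxicity, read by resazurin assay, with a stated time of 3 days; a higher number here means a weaker inhibitor, a lower number a stronger inhibitor:

- compound 1, `CCN(CC)c1cc2[nH]c(C3CCCCC3)nc2cc1NC(=O)c1cnccn1`: > 100 ug/mL
- compound 2, `CCCCOC(=O)Nc1cc2nc(C3CCCCC3)[nH]c2cc1N(C)C`: > 100 ug/mL
- compound 3, `CCCN(CCC)c1cc2[nH]c(C3CCCCC3)nc2cc1NC(=O)c1ccccc1`: > 100 ug/mL

Compound 1 stands at > 100 ug/mL in this assay, and this is a limit of the assay rather than a number. Compound 2 likewise gives > 100 ug/mL, again a limit. Compound 3 gives > 100 ug/mL, also a limit. In other words, every measured value sits at the limit of > 100 ug/mL in this assay, at which 3 of the 3 values shown sit, so the three compounds cannot be put in any order against each other, and compound 1 is neither stronger nor weaker than its two neighbours on the evidence shown.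

Compound 4, `CCN(CC)c1cc2[nH]c(C3CCCCC3)nc2cc1NC(=O)c1cccc(Br)c1`, differs from compound 1 in one place: 3-bromophenyl in place of pyrazin-2-yl on a carbonyl carbon. Going by the values given here, no measured pair of compounds here shows what such an exchange on the carbonyl carbon does in this assay, so the expectation can rest only on the fact that every measured value is a limit. On that basis the step from compound 1 to compound 4 is expected to be a number no higher from compound 1 to compound 4 (the limit leaves the size open), that is, nothing beyond the usual scatter. Compound 4 is therefore estimated to give 100 ug/mL, with a range from 50 ug/mL to 200 ug/mL, and most likely to be reported only as a limit.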

Compound 4, half-maximal inhibitory concentration: > 100 ug/mL
Compound 4: no number, only a limit (the forecaster's own chance of this, stated with the estimate: 85%); the middle value lies on the limit itself.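

In this assay compound 4 gives > 100 ug/mL, which is a limit of the assay and not a number. Going by these compounds alone, compound 1 also stands only at a limit, so no step between compound 1 and compound 4 can be read. The compounds shown leave open how 3-bromophenyl in place of pyrazin-2-yl on a carbonyl carbon acts in this assay, and how the four compounds rank: the limit of > 100 ug/mL in this assay, at which 4 of the 4 values shown sit.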